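Two Aryl Amides, a Limit, and an Untested Carbamate

The compounds below may be only part of what the source reports. "The series", "measured", "known", "first", "only" and "open" are said of these compounds alone.

Measured so far, in a functional assay on WI-38 VA13 cells (Homo sapiens) for cytotoxicity; a lower number here means that less compound is needed, a higher number that more compound is needed for the effect:
- compound 1, `O=C(Nc1ccc2nc(NC(=O)C3CCCCC3)sc2c1)c1ccccc1Oc1ccccc1`, gives 0.1 ug/mL.
- compound 2, `O=C(Nc1ccc2nc(NC(=O)C3CCCCC3)sc2c1)c1cccc(Oc2ccccc2)c1`, gives only a limit of > 4 ug/mL.
- compound 3, `O=C(Nc1ccc2nc(NC(=O)C3CCCCC3)sc2c1)c1c(Cl)cccc1Cl`, gives 0.015 ug/mL.

Of the two values that are numbers, compound 3 gives the lower one, and its gap to compound 1 lies beyond the usual scatter. For compound 2 the assay reports only a limit, (the limit of > 4 ug/mL in this assay, at which 1 of the 3 values shown sits), so no number stands beside it.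

Compound 4, `CC(C)COC(=O)Nc1ccc2nc(NC(=O)C3CCCCC3)sc2c1`, has not been measured. It differs from compound 3 in one place: isobutoxy in place of 2,6-dichlorophenyl on a carbonyl carbon. Among the measured compounds shown here, nothing among the measured compounds tests an isobutoxy on that carbonyl carbon, so the step rests on the structural change alone. For the measured compounds named here, the two numbers that exist both belong to compounds carrying a substituted phenyl on the carbonyl carbon, and the one compound without a number, compound 2, also carries one; no measured step shows what a non-aromatic group does there.

A step in the direction of a higher number is expected, of the size a 20-fold higher number from compound 3 to compound 4 (1.30 log units; beyond the scatter), since the 2,6-dichlorophenyl that gave compound 3 its low value is gone. Compound 4 is therefore estimated to give about 0.3 ug/mL in this assay, most likely between 0.03 ug/mL and 4 ug/mL.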

Compound 4, half-maximal effective concentration: 0.72 ug/mL
Beside the measured number, compound 4's estimate is 2.4-fold (0.38 log units) below it, and the stated range covers the measured number.
By their numbers in this assay, from the lowest: compound 3; then compound 1; then compound 4. At a limit, above all of these: compound 2.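

In this assay, among the compounds shown here, putting isobutoxy in place of 2,6-dichlorophenyl on a carbonyl carbon whose other neighbour is an amide-type nitrogen gives a 48-fold higher number from compound 3 to compound 4 (1.68 log units; beyond the scatter), the first measured step at this position and a large one. Compound 4 carries no ring in that place and still gives a number, 0.72 ug/mL, so an aromatic ring on this carbonyl carbon is not required for a measured value, even though the value of compound 3 with its 2,6-dichlorophenyl is much lower. Nor does a ring in that place ensure a number, as compound 2 carries one and gives only a limit: the limit of > 4 ug/mL in this assay, at which 1 of the 4 values shown sits.

For the compounds shown here, the single step removes the ring and both chlorine atoms and brings in an oxygen on the carbonyl carbon all at once, so it does not show how much of the rise goes with each of these changes. Open as well is what a phenoxy group, which would keep the oxygen together with a ring, or an unbranched butyl chain or an amine on the same carbonyl carbon would give in this assay.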